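The compounds below may be only part of what the source reports. "The series", "measured", "known", "first", "only" and "open" are said of these compounds alone.

Working notes on the series.

Compound 1 `CCCC(=O)N1CCC(NS(=O)(=O)c2ccc(NC(=O)C3CCCCC3)c3ccccc23)CC1` gives 6.1 nM in an in vitro functional assay on CHO/Galpha16 cells for antagonist activity at C-C chemokine receptor type 8 (Homo sapiens), read by FLIPR (on this read-out higher numbers stand for weaker inhibition and lower numbers for stronger inhibition), the lowest of the three numbers recorded so far. Its two analogues differ only in the group on the carbonyl carbon next to the amide-type nitrogen. Compound 2 `CCCC(=O)N1CCC(NS(=O)(=O)c2ccc(NC(=O)C(CC)CC)c3ccccc23)CC1` gives 639 nM; the step of a 100-fold higher number from compound 1 to compound 2 (2.02 log units; beyond the scatter) is the large one in the set. Compound 3 `CCCC(=O)N1CCC(NS(=O)(=O)c2ccc(NC(=O)c3ccc(CC)cc3)c3ccccc23)CC1` gives 10.8 nM, and the step of a 1.8-fold higher number from compound 1 to compound 3 (0.25 log units; within the scatter) stays within the scatter. Between them, a 59-fold lower number from compound 2 to compound 3 (1.77 log units; beyond the scatter).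

Compound 4 `CCCC(=O)N1CCC(NS(=O)(=O)c2ccc(NC(=O)c3ccccn3)c3ccccc23)CC1` has not been measured. It differs from compound 1 by pyridin-2-yl in place of cyclohexyl on a carbonyl carbon. The incoming group is a six-membered aromatic ring with one hetero atom, so the ring-for-ring comparison of compound 1 with compound 3 bears most directly on it, and that step was within the scatter. The large loss seen for compound 2 came with an acyclic group, which compound 4 does not carry. For the measured compounds named here, an added hydrogen-bond acceptor has no precedent in this set, so some widening of the range is appropriate.

Compound 4 is therefore expected to give about 15 nM in this assay, roughly 4 nM to 60 nM, a step estimated as a 2.5-fold higher number from compound 1 to compound 4 (0.39 log units; beyond the scatter).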

Compound 4, half-maximal inhibitory concentration: 41.7 nM
Compound 4: middle estimate off by 2.8-fold (0.44 log units), on the low side; the range from low to high includes it.
By their numbers in this assay, from the lowest: compounds 1 and 3 (each within the scatter of the next); then compound 4; then compound 2.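

The position does not treat all ring groups alike: pyridin-2-yl in place of cyclohexyl gives a 6.8-fold higher number from compound 1 to compound 4 (0.83 log units; beyond the scatter), and in place of 4-ethylphenyl it gives a 3.9-fold higher number from compound 3 to compound 4 (0.59 log units; beyond the scatter), whereas compounds 1 and 3 lay within the scatter of each other in this assay. Ring identity therefore matters here, yet pyridin-2-yl in place of pentan-3-yl still gives a 15-fold lower number from compound 2 to compound 4 (1.19 log units; beyond the scatter), so all three cyclic groups shown keep lower numbers than the acyclic one in compound 2, with no exception among these four compounds. No measurement offered here accounts for the difference between these groups.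

From the compounds shown here alone, whether the ring nitrogen or the absence of the ethyl group sets compound 4 apart from compound 3 stays open, and an unsubstituted phenyl would separate the two. Pyridin-4-yl would show whether the placing of the ring nitrogen matters.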